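Cyclopropylamino in Place of the Hydroxyethoxy Tail

This account rests on a few compounds, and the source may have more. Where it says the series, first, only, none or still open, it means among the compounds named here.

Compound 1 `c1ccc(COc2ccc(OCCOCCNc3ccccc3)cc2)cc1`: > 100000 nM
Compound 2 `OCCOCCOCCOc1ccc(OCc2ccccc2)cc1`: 59400 nM
Compound 3 `c1ccc2cc(OCCOCCNC3CCCC3)ccc2c1`: 40600 nM

Of the compounds shown here, three have been measured in a functional assay on SK-OV-3 cells (Homo sapiens) for inhibition, read by CCK-8 assay, with a stated time of 70 h; on this read-out lower numbers stand for stronger inhibition and higher numbers for weaker inhibition. Compound 1 reached only a limit in this assay, > 100000 nM, which is not a number. Compound 2 gives 59400 nM in this assay. Compound 3, built on a different core, gives 40600 nM. Compound 2 thus sits among two measured numbers, and its gap to compound 3 lies within the usual scatter, so no order between them can be read.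

Going by the values given here, the one step measured so far, an at least 1.6-fold lower number from compound 1 to compound 2 (0.22 log units; that floor lies within the scatter), brings an anilino-bearing compound to a hydroxyethoxy-bearing one; its floor is within the scatter, and the limit of > 100000 nM in this assay, at which 1 of the 3 values shown sits, is all that bounds it.

Compound 4 `c1ccc(COc2ccc(OCCOCCNC3CC3)cc2)cc1` has not been measured. The change from compound 2 is cyclopropylamino in place of 2-hydroxyethoxy on a saturated chain carbon, two bonds along the chain from an oxygen on a saturated carbon. Among the compounds with values here, no measured step covers this exact change; the only related step is the one from compound 1 to compound 2, which moved away from an amine. Compound 3 carries an aliphatic amine on its chain and gives a number within scatter of compound 2. The estimate for compound 4 is therefore a step of a 1.3-fold lower number from compound 2 to compound 4 (0.12 log units; within the scatter) in this assay, within the scatter. Compound 4 is expected at 45000 nM, between 15000 nM and 100000 nM.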

Compound 4, half-maximal inhibitory concentration: 47200 nM
Estimate against measurement, compound 4: 1.0-fold (0.02 log units) below; measured number inside the range.
By their numbers in this assay, from the lowest: compounds 3, 4 and 2 (each within the scatter of the next). At a limit, above all of these: compound 1.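

At this place on the chain, two bonds along from an oxygen on a saturated carbon, cyclopropylamino in place of 2-hydroxyethoxy gives in this assay a 1.3-fold lower number from compound 2 to compound 4 (0.10 log units; within the scatter), so the amine tail and the hydroxyethoxy tail cannot be told apart on the shared core. On the amine nitrogen itself, cyclopropyl in place of phenyl gives an at least 2.1-fold lower number from compound 1 to compound 4 (0.32 log units; beyond the scatter), the only step shown so far that clears the scatter, and what it gives is a floor rather than a full size. Compound 1 stands at a limit and not at a number, and that limit alone bounds the step: the limit of > 100000 nM in this assay, at which 1 of the 4 values shown sits.

The compounds shown leave open whether a different group on that nitrogen, such as methyl or cyclohexyl, or a longer chain carrying the amine, would move the number beyond the scatter from compound 2. They also leave open what the core contributes, as compound 3 differs from compound 4 both in its core and in the group on its amine, so the two changes cannot be separated.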